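From azido to amino: the step to compound 4

The compounds below may be only part of what the source reports. "The series", "measured", "known", "first", "only" and "open" are said of these compounds alone.

Measured in a functional assay on SKW3 cells (Homo sapiens) for antiproliferative activity, read by WST assay, with a stated time of 3 days; on this read-out higher numbers stand for weaker inhibition and lower numbers for stronger inhibition:
Compound 1 `Nc1cc(=O)[nH]c(=O)n1[C@@H]1O[C@H](CO)[C@@H](O)[C@H]1O`: > 50000 nM (a limit)
Compound 2 `O=c1[nH]c(=O)n([C@@H]2O[C@H](CO)[C@@H](O)[C@H]2O)c(I)c1F`: > 50000 nM (a limit)
Compound 3 `[N-]=[N+]=Nc1c(F)c(=O)[nH]c(=O)n1[C@@H]1O[C@H](CO)[C@@H](O)[C@H]1O`: 400 nM

Going by the values given here, compound 3 holds the only true number in this small set, since the other two results are limits, as the limit of > 50000 nM in this assay, at which 2 of the 3 values shown sit, records. Its azido group is now replaced to give compound 4 `Nc1c(F)c(=O)[nH]c(=O)n1[C@@H]1O[C@H](CO)[C@@H](O)[C@H]1O`, which has amino in place of azido on an aromatic carbon.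

Among the compounds with values here, only one measured step changes the group on this carbon. That step, an at least 120-fold lower number from compound 2 to compound 3 (2.09 log units; beyond the scatter), is large and brought azido in place of iodo, so the group here can matter greatly in this assay. Within the data shown here, no measured step has amino entering. Compound 1 carries amino on an aromatic carbon but has no fluoro group, and its value of > 50000 nM is a limit. Compound 4 keeps the fluoro group, so that limit is only a loose guide.

A sizeable move toward weaker inhibition therefore seems likely, though with wide uncertainty. The expected change is a 5.0-fold higher number from compound 3 to compound 4 (0.70 log units; beyond the scatter). For compound 4 the estimated value is 2000 nM, with an expected range from 200 nM to 40000 nM.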

Compound 4, half-maximal inhibitory concentration: 600 nM
Compound 4: the middle estimate sits 3.3-fold (0.52 log units) above what was measured; low and high end bracket the measured number.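

In this assay, amino in place of azido gives a 1.5-fold higher number from compound 3 to compound 4 (0.18 log units; within the scatter), so this carbon tolerates a change from a group of 3 heavy atoms to one of 1 heavy atom, and azido is not unique among the groups seen here. Amino also separates clearly from iodo, with an at least 83-fold lower number from compound 2 to compound 4 (1.92 log units; beyond the scatter), so two different groups on this carbon now stand apart from iodo rather than one. The comparison with the compound lacking fluoro adds something new, since fluoro in place of hydrogen gives an at least 83-fold lower number from compound 1 to compound 4 (1.92 log units; beyond the scatter), which shows that amino on this carbon goes with the stronger result only when the fluoro group is present, though this step and the one from iodo each rest on a limit rather than a true number: the limit of > 50000 nM in this assay, at which 2 of the 4 values shown sit.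

The compounds shown leave open whether a methylamino group, a hydroxyl or a nitrile on this carbon would stay level with azido and amino or fall away as iodo does. They also leave open whether chloro or methyl could take the place of the fluoro group while amino stays in place.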